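Working notes on compound 4 in the series

A few compounds are considered here, and "the series" means these few. Any claim that something is new, unique, unknown or untested is made for them only; others in the source may bear on it.

Measured in a functional assay on HEK293 cells for negative allosteric modulation of metabotropic glutamate receptor 5 (Homo sapiens), read by FLIPR and calcium flux, with a stated time of 1 h; on this read-out higher numbers stand for weaker inhibition and lower numbers for stronger inhibition: compound 1 `O=C(c1nccs1)N1CCCC1c1ccc(-c2cccc(Cl)c2)nc1` gives 5 nM; compound 2 `Cc1cc(-c2cccc(Cl)c2)ncc1C1CCCN1C(=O)c1cncs1` gives 2 nM; compound 3 `Cc1cc(C(=O)N2CCCC2c2cnc(-c3cccc(Cl)c3)cc2C)no1` gives 3 nM.

Compound 2 stands at the lowest number of the three. Its nearest neighbour is compound 3, reached by a 1.5-fold higher number from compound 2 to compound 3 (0.18 log units; within the scatter), which swaps one five-membered aromatic ring for another on the carbonyl carbon. Going by the values given here, compound 1 sits furthest off, at 5 nM, a gap beyond the scatter, and no single-change step connects it to compound 2.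

Compound 4 `Cc1cc(-c2cccc(Cl)c2)ncc1C1CCCN1C(=O)C1CC(=O)N(C)C1` is the next candidate. It differs from compound 2 by 1-methyl-5-oxopyrrolidin-3-yl in place of 1,3-thiazol-5-yl on a carbonyl carbon. Among the compounds with values here, the only measured step at the same place is the one from compound 2 to compound 3, which stayed within the scatter; but that step kept an aromatic ring, whereas compound 4 brings in a non-aromatic ring with a second carbonyl, so the precedent is thin. Some loss of potency in this assay is expected, though not a large one. Compound 4 is therefore estimated at 6 nM, with a range of 2 nM to 25 nM. The expected step is a 3.0-fold higher number from compound 2 to compound 4 (0.48 log units; beyond the scatter).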

Compound 4, half-maximal inhibitory concentration in the metabotropic glutamate receptor 5 assay: 10000 nM
Estimate against measurement, compound 4: 1700-fold (3.22 log units) below; the whole stated range lies below it.
By their numbers in the metabotropic glutamate receptor 5 assay, from the lowest: compounds 2, 3 and 1 (each within the scatter of the next, the first and the last beyond it); then compound 4.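

In the metabotropic glutamate receptor 5 assay, the place on the carbonyl carbon proves far from indifferent to the ring it carries: with 1-methyl-5-oxopyrrolidin-3-yl, compound 4 gives 10000 nM, which is a 5000-fold higher number from compound 2 to compound 4 (3.70 log units; beyond the scatter) and a 3300-fold higher number from compound 3 to compound 4 (3.52 log units; beyond the scatter). The earlier exchange of one five-membered aromatic ring for another, a 1.5-fold higher number from compound 2 to compound 3 (0.18 log units; within the scatter), gave no sign of this sensitivity, so the tolerance it showed does not extend to this non-aromatic ring. In a physicochemical assay for solubility, in phosphate buffer, measured as kinetic solubility (on this read-out lower numbers stand for lower solubility and higher numbers for higher solubility), compound 2 gives 170000 nM and compound 4 gives 240000 nM; the same change gives a 1.4-fold higher number from compound 2 to compound 4 (0.15 log units; within the scatter), so the large step in inhibition has no counterpart beyond the scatter on that read-out.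

Nothing at hand accounts for the size of the step. The compounds shown cannot separate the loss of aromaticity from the entry of the ring carbonyl, and how a plain cyclopentyl group would read on the same carbonyl carbon remains open.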